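The compounds below may be only part of what the source reports. "The series", "measured", "known", "first", "only" and "open" are said of these compounds alone.

Compound 2 `C=CCNc1n[n+]([O-])c2ccccc2[n+]1[O-]` gives 3000 nM in a functional assay on MOLT-4 cells (Homo sapiens) for cytotoxicity, read by MTT assay, with a stated time of 48 h (on this read-out lower numbers stand for stronger inhibition and higher numbers for weaker inhibition), and stands at the high end of the three numbers recorded. Compound 1 `[O-][n+]1nc(NC2CCCCC2)[n+]([O-])c2ccccc21` gives 1300 nM and compound 3 `[O-][n+]1nc(NCc2ccccc2)[n+]([O-])c2ccccc21` gives 2200 nM; the step of a 1.4-fold lower number from compound 2 to compound 3 (0.13 log units; within the scatter) lies within the scatter, whereas a 2.3-fold higher number from compound 1 to compound 2 (0.36 log units; beyond the scatter) lies beyond it. Compound 4 `[O-][n+]1nc(NC2CC2)[n+]([O-])c2ccccc21` differs from compound 2 by cyclopropyl in place of allyl on a nitrogen on an aromatic ring, that is, allylamino to cyclopropylamino. For the measured compounds named here, the one measured step that bears on this nitrogen substituent, a 2.3-fold higher number from compound 1 to compound 2 (0.36 log units; beyond the scatter), shows that a ring on that nitrogen went with a lower number than allyl. A modest step in the same direction is therefore expected, a 1.5-fold lower number from compound 2 to compound 4 (0.18 log units; within the scatter). Compound 4 is estimated at 2000 nM, within a range of 1000 nM to 4000 nM.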

Compound 4, half-maximal inhibitory concentration: 1900 nM
The estimate for compound 4 lay 1.1-fold (0.02 log units) above the measured number; measured number inside the range.
By their numbers in this assay, from the lowest: compounds 1, 4, 3 and 2 (each within the scatter of the next, the first and the last beyond it).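

In this assay the exchange of allyl for cyclopropyl, the same carbons now closed into a ring, gives a 1.6-fold lower number from compound 2 to compound 4 (0.20 log units; within the scatter) and so does not separate the two groups on this nitrogen. Cyclopropyl in place of cyclohexyl gives a 1.5-fold higher number from compound 1 to compound 4 (0.16 log units; within the scatter) as well, so compound 4 cannot be told apart from compound 1 or compound 2, even though those two differ beyond the scatter. No evidence at hand accounts for these numbers. Still open, as far as these compounds go, is whether a longer chain, or a substituent carrying an amine or a carboxylic acid, on this nitrogen would stand apart from these values.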